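Swapping the fluorobenzyl for a dimethoxybenzyl group

A few compounds are considered here, and "the series" means these few. Any claim that something is new, unique, unknown or untested is made for them only; others in the source may bear on it.

Three compounds have been measured in a functional assay on HeLa cells (Homo sapiens) for antiproliferative activity, read by sulforhodamine B assay, with a stated time of 48 h; a lower number here means a stronger inhibitor of growth, a higher number a weaker inhibitor of growth:
Compound 1 `O=C(NCc1cn(Cc2ccc(F)cc2)nn1)c1cn(-c2ccccc2)nc1-c1ccccc1` gives 1600 nM.
Compound 2 `COc1ccc(Cn2cc(CNC(=O)c3cn(-c4ccccc4)nc3-c3ccccc3)nn2)cc1` gives 6900 nM.
Compound 3 `O=C(NCc1cn(Cc2ccc(F)cc2)nn1)c1cn(-c2ccccc2)nc1-c1ccc(F)cc1` gives 1200 nM.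

All three share the same core and differ only in the groups on the two outer rings. Compound 3 gives the lowest number of the three, but the step of a 1.3-fold lower number from compound 1 to compound 3 (0.12 log units; within the scatter) lies within the usual scatter, so compound 1 and compound 3 cannot be ranked; the gap from compound 3 to compound 2 is clearly larger.

Compound 4 `COc1cc(Cn2cc(CNC(=O)c3cn(-c4ccccc4)nc3-c3ccc(F)cc3)nn2)cc(OC)c1` is the next step from compound 3: 3,5-dimethoxyphenyl in place of 4-fluorophenyl on a saturated chain carbon bound to an aromatic nitrogen. Going by the values given here, the one measured step that bears on this is the swap of the same fluorine for a methoxy group, a 4.3-fold higher number from compound 1 to compound 2 (0.63 log units; beyond the scatter), a modest move to a weaker inhibitor. Compound 4 carries two methoxy groups instead of one and loses the fluorine, so a weakening of similar or somewhat larger size is expected, a 3.8-fold higher number from compound 3 to compound 4 (0.57 log units; beyond the scatter). Compound 4 is therefore estimated at 4500 nM, with a range from 1500 nM to 14000 nM.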

Compound 4, concentration for 50% growth inhibition: 360 nM
Compound 4: middle estimate off by 13-fold (1.10 log units), on the high side, outside the stated range (below it).
By their numbers in this assay, from the lowest: compound 4; then compounds 3 and 1 (each within the scatter of the next); then compound 2.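

In this assay the swap of 4-fluorophenyl for 3,5-dimethoxyphenyl on a saturated chain carbon bound to an aromatic nitrogen gives a 3.3-fold lower number from compound 3 to compound 4 (0.52 log units; beyond the scatter) and so shows that a change at this place can strengthen growth inhibition, not only weaken it. The other swap at this place gives a 4.3-fold higher number from compound 1 to compound 2 (0.63 log units; beyond the scatter) and runs the opposite way, so the presence of a methoxy group does not by itself set the direction of the step, although that pair also lacks the fluorine on the other outer ring. Nothing measured here explains this reversal.

Still open, on these data alone, is whether the stronger inhibition needs both methoxy groups, and whether it holds without that fluorine. Also open, as far as these compounds go, is how hydroxy groups, amines or a third methoxy group would behave at this place.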